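A few compounds are considered here, and "the series" means these few. Any claim that something is new, unique, unknown or untested is made for them only; others in the source may bear on it.

Measured so far:
compound 1 `O=C(CCCCCc1ccccc1)c1nc2ncccc2[nH]1` — 1230 nM
compound 2 `O=C(CCCCCCc1ccccc1)c1nc(C(=O)C(F)(F)F)co1` — 123 nM

In an assay on HEK-293T cells for inhibition of diacylglycerol lipase-alpha (Homo sapiens), read by colorimetric assay (a lower number here means a stronger inhibitor, a higher number a weaker inhibitor), compound 2 gives 123 nM and stands as the lower of the two numbers; compound 1 gives 1230 nM in this assay, and the gap between the two lies well beyond the usual scatter, so compound 2 is the stronger of the pair as far as this assay goes. The two compounds differ in more than one place, so no single structural change can be read out of that gap.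

Compound 3 `CC(C)(C)C(=O)c1coc(C(=O)CCCCCCc2ccccc2)n1` keeps the core and the chain of compound 2 and differs in one place: tert-butyl in place of trifluoromethyl on a carbonyl carbon. Within the data shown here, no measured pair in this set shows this change, so its size is unknown from the numbers at hand. The expectation is a loss in this assay, with a step beyond the scatter rather than a flat result. Compound 3 is therefore estimated at 3000 nM in this assay, with a range from 600 nM to 15000 nM. The expected step of a 24-fold higher number from compound 2 to compound 3 (1.39 log units; beyond the scatter) reflects that estimate, to be checked against the measurement.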

Compound 3, half-maximal inhibitory concentration: 479 nM
For compound 3 the middle estimate is 6.3-fold (0.80 log units) above the measured one, and the stated range ends above it.
By their numbers in this assay, from the lowest: compound 2; then compound 3; then compound 1.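

In this assay, among these compounds, the change from trifluoromethyl to tert-butyl on a carbonyl carbon gives a 3.9-fold higher number from compound 2 to compound 3 (0.59 log units; beyond the scatter) and is the first step that can be read at a single place. The step lies beyond the scatter but is modest, so this position responds to the change while compound 3, with no fluorine in the group, still gives 479 nM and stays below compound 1 at 1230 nM in the printed values. The two groups match in heavy-atom count and neither carries a ring, a hydrogen-bond donor or acceptor, or a net charge, and no measurement at hand identifies what underlies the step.

Open, going by these compounds, is how the same carbonyl carbon would respond to a different kind of group, such as a methyl, an amine or a carboxylic acid, since a single pair gives no trend at this position. Also open, on these data alone, is whether the step would keep its size with a longer chain or on the core of compound 1.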